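This account rests on a few compounds, and the source may have more. Where it says the series, first, only, none or still open, it means among the compounds named here.

In a functional assay on SW-620 cells (Homo sapiens) for cytotoxicity, read by colorimetric assay (a lower number here means a stronger inhibitor, a higher number a weaker inhibitor), compound 1 `O=C(/C=C/c1ccc(CN2C(=O)/C(=C3\Nc4ccccc4\C3=N/O)c3cc(Cl)ccc32)cc1)NO` gives 80 nM. Going by the values given here, compound 2 `O=C(NO)c1ccc(CN2C(=O)/C(=C3\Nc4ccccc4\C3=N/O)c3cccc(Cl)c32)cc1` gives 90 nM, and these two numbers lie within the scatter of each other, so compound 1 cannot be told apart from the only other measured compound. Compound 3 `O=C(/C=C/c1ccc(CN2C(=O)/C(=C3\Nc4ccccc4\C3=N/O)c3cc(F)ccc32)cc1)NO` differs from compound 1 in one substituent: fluoro in place of chloro on an aromatic carbon. Among the compounds with values here, no measured pair shows this change. In this assay no change beyond the scatter is expected, with the estimated 1.3-fold higher number from compound 1 to compound 3 (0.10 log units; within the scatter) staying inside it. The value expected for compound 3 is 100 nM, with a range of 40 nM to 250 nM.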

Compound 3, half-maximal inhibitory concentration: 50 nM
Estimate against measurement, compound 3: 2.0-fold (0.30 log units) above; low and high end bracket the measured number.
By their numbers in this assay, from the lowest: compounds 3, 1 and 2 (each within the scatter of the next).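

In this assay, going by these compounds alone, fluoro in place of chloro on this aromatic carbon gives a 1.6-fold lower number from compound 1 to compound 3 (0.20 log units; within the scatter) and is the first step that changes a single place. At this position of the core of compound 1, the two halogens therefore cannot be told apart, which the earlier pair, differing in more than one place, could not show. Nothing measured here speaks to the reason for this. Still open, going by these compounds, is whether a hydrogen, a methoxy group or an amine on this carbon would also stay within the scatter of compound 1.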